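The compounds below may be only part of what the source reports. "The series", "measured", "known", "first", "only" and "open" are said of these compounds alone.

The three measured compounds, each tested in an ADME assay for permeability, using PAMPA, with a stated time of 4 h; on this read-out lower numbers stand for lower permeability and higher numbers for higher permeability:

Compound 1, `Cn1c(COc2cccc(C(=O)O)c2)nc2ccc(Oc3cccc(Cl)n3)cc21`, gives 7.6 10^-6 cm/s.
Compound 2, `Cc1cccc(Oc2ccc3nc(COc4cccc(C(=O)O)c4)n(C)c3c2)n1`, gives 2.7 10^-6 cm/s.
Compound 3, `Cc1ccc(Oc2ccc3nc(COc4cccc(C(=O)O)c4)n(C)c3c2)nc1`, gives 4.8 10^-6 cm/s.

All three share one core and differ only in the small aromatic ring attached through an oxygen. Compound 3 is close to both neighbours on this read-out: the gap a 1.6-fold lower number from compound 1 to compound 3 (0.20 log units; within the scatter) and the gap a 1.8-fold higher number from compound 2 to compound 3 (0.25 log units; within the scatter) both lie within the usual scatter of repeated measurements. Only the change from chloro to methyl, a 2.8-fold lower number from compound 1 to compound 2 (0.45 log units; beyond the scatter), was a step of any note.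

Compound 4, `Cc1cccnc1Oc1ccc2nc(COc3cccc(C(=O)O)c3)n(C)c2c1`, is the next case. Its change from compound 3 is 3-methylpyridin-2-yl in place of 5-methylpyridin-2-yl on an oxygen on an aromatic ring. The methyl group stays on the same kind of ring; only its position on that ring moves.

Within the data shown here, the one earlier step that most resembles this, the move of the methyl between two positions on the same ring, is a 1.8-fold higher number from compound 2 to compound 3 (0.25 log units; within the scatter), which stayed within the scatter. Moving the methyl once more is therefore expected to give no step beyond the scatter in this assay, with the estimated change a 1.1-fold lower number from compound 3 to compound 4 (0.03 log units; within the scatter). For compound 4 the expected value is 4.5 10^-6 cm/s, with a likely range from 2.5 10^-6 cm/s to 8 10^-6 cm/s.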

Compound 4, apparent permeability: 6 10^-6 cm/s
For compound 4 the middle estimate is 1.3-fold (0.12 log units) below the measured one, and the stated range covers the measured number.
By their numbers in this assay, from the lowest: compounds 2, 3, 4 and 1 (each within the scatter of the next, the first and the last beyond it).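

Within the methyl series in this assay, moving the methyl to give the 3-methylpyridin-2-yl group stays within the scatter of the 5-methyl compound (a 1.3-fold higher number from compound 3 to compound 4 (0.10 log units; within the scatter)), yet it separates from the 6-methyl compound (a 2.2-fold higher number from compound 2 to compound 4 (0.35 log units; beyond the scatter)). The position of one methyl on this ring can therefore produce a modest step beyond the scatter, which the earlier move between the 6-methyl and 5-methyl compounds did not show. The 3-methyl compound also stays within the scatter of the chloro compound (a 1.3-fold lower number from compound 1 to compound 4 (0.10 log units; within the scatter)), as compound 3 did, so swapping chloro for methyl gave a step beyond the scatter only in compound 2; nothing available explains these differences.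

As far as these compounds go, it remains open whether 3-chloropyridin-2-yl would sit with the methyl compounds or with the 6-chloro compound on this read-out. Also open, from the compounds shown here alone, is how a methoxy group or a nitrile on this ring, or an amide in place of the carboxylic acid, would read in this assay ( the same test ).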